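The source may report more compounds than this note shows. Statements on the series, on what has been measured and on what is new or still open speak of the compounds shown alone.

Of the compounds shown here, three built on one core have been measured in a functional assay on HT-29 cells (Homo sapiens) for cytotoxicity, read by sulforhodamine B assay (on this read-out higher numbers stand for weaker inhibition of growth and lower numbers for stronger inhibition of growth), so far. There compound 1 `CC1=CC[C@@H]([C@@](C)(O)CCCC(C)(C)NC=S)CC1` gives 47900 nM and compound 2 `CC1=CC[C@@H]([C@@](C)(O)CCCC(C)(C)NC(=S)N/N=C\c2ccccc2)CC1` gives 36500 nM while compound 3 `CC1=CC[C@@H]([C@@](C)(O)CCCC(C)(C)NC(=S)N/N=C\c2ccc(C)cc2)CC1` gives 80400 nM on the same scale. Compound 3 therefore stands level with compound 1, the two values lying within the scatter of each other, and its number lies beyond the scatter above that of compound 2.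

For the measured compounds named here, still unmeasured is compound 4 `CC1=CC[C@@H]([C@@](C)(O)CCCC(C)(C)NC(=S)N/N=C\c2ccc(N(C)C)cc2)CC1` in which dimethylamino stands in place of methyl on an aromatic carbon dimethylamino in place of methyl on an aromatic carbon as the only change from compound 3. Going by the values given here, two measured steps bear on this. The closer one is a 2.2-fold higher number from compound 2 to compound 3 (0.34 log units; beyond the scatter) where methyl replaced hydrogen on the same aromatic carbon. The other is a 1.3-fold lower number from compound 1 to compound 2 (0.12 log units; within the scatter) which introduced the whole aromatic portion. Among the compounds with values here, neither step is large, but no measured compound carries dimethylamino, so the data give only a weak hint of direction. A small drift toward the value of compound 2 is expected, and no step beyond the scatter. The estimated change is a 1.3-fold lower number from compound 3 to compound 4 (0.13 log units; within the scatter) and it remains uncertain. Compound 4 is estimated at 60000 nM with a range of 25000 nM to 120000 nM expected for repeated measurements.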

Compound 4, concentration for total growth inhibition: > 100000 nM
Compound 4 ended at the assay's limit; the forecaster's own chance of this, stated with the estimate: 10%; middle value at least 1.6-fold (0.22 log units) from the limit.
By their numbers in this assay, from the lowest: compounds 2, 1 and 3 (each within the scatter of the next, the first and the last beyond it). At a limit, above all of these: compound 4.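

In this assay compound 4 gives > 100000 nM, which is a limit of the assay and not a number. At this aromatic carbon, para to a large group, replacing hydrogen with dimethylamino gives an at least 2.7-fold higher number from compound 2 to compound 4 (0.43 log units; beyond the scatter), so a second group at this position moves the read-out beyond the scatter in the same direction as methyl did in a 2.2-fold higher number from compound 2 to compound 3 (0.34 log units; beyond the scatter), towards weaker inhibition of growth. Set against methyl itself, the change reads only as an at least 1.2-fold higher number from compound 3 to compound 4 (0.09 log units; that floor lies within the scatter), so compound 4 may stand level with compound 3 or well beyond it, and the true size of the change stays unread, as the read-out stops at a limit: the limit of > 100000 nM in this assay, at which 1 of the 4 values shown sits.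

The compounds shown leave open whether any group at this aromatic carbon would move the number the other way, or whether a methoxy group, a primary amine or a carboxylic acid there would also bring weaker inhibition of growth. They also leave open whether dimethylamino would give the same result on another carbon of the ring, and what the change does in any other assay.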